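Swapping Trifluoromethyl for Methyl on the Aryl Ring

The source may hold more compounds than are shown below. What is called first, only, known or untested is meant among the compounds shown, and "the series" means these compounds.

Measured so far:
compound 1, `FC(F)(F)c1ccc(NC2=NCCC3(CCCCC3)S2)cc1`, 2.18
compound 2, `CNC1=NCCC2(CCCCC2)S1`, 0.88
compound 3, `Cc1cccc(C(C)C)c1NC1=NCCC2(CCCCC2)S1`, 2.36

All three share one core and differ only in the group attached to the nitrogen. In a physicochemical assay for lipophilicity, measured as octanol-water partition, at pH 7.4 (a higher number here means a more lipophilic compound, a lower number a more polar compound), compound 1 gives 2.18. That places it second highest of the three numbers. Compound 3 gives 2.36, a number within the usual scatter of that of compound 1, so the two cannot be told apart. Compound 2 gives 0.88, a number well below compound 1 and beyond the scatter.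

The next compound is compound 4, `Cc1ccc(NC2=NCCC3(CCCCC3)S2)cc1`. It keeps the aryl ring of compound 1 and changes one substituent: methyl in place of trifluoromethyl on an aromatic carbon. The place is an aromatic carbon of a six-membered aromatic ring of carbon only, para to a large group.

Among the measured compounds shown here, no measured pair shows this exact change, so the step is an expectation only. In this assay the step from compound 1 to compound 4 is expected to be small and downward, roughly at the edge of the scatter, a number 0.33 log units lower from compound 1 to compound 4 (beyond the scatter). Starting from the value of compound 1, 2.18, compound 4 is expected at about 1.85, with a range from 1.45 to 2.25.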

Compound 4, distribution coefficient: 1.56
Estimate against measurement, compound 4: 0.29 log units above, and the stated range covers the measured number.
By their numbers in this assay, from the lowest: compound 2; then compound 4; then compounds 1 and 3 (each within the scatter of the next).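

Among the compounds shown here, this is the first pair in the set that differs in only one place, so a single substituent can be read on its own rather than a whole group on the nitrogen. In this assay, putting methyl in place of trifluoromethyl on an aromatic carbon, para to a large group, gives a clear step: a number 0.62 log units lower from compound 1 to compound 4 (beyond the scatter), so this substituent is not a silent part of the molecule in this measurement. Nothing available here accounts for the size or direction of that step, so the pair records what happens without explaining it.

As far as these compounds go, it remains open where a chlorine atom, a methoxy group, a nitrile or a plain hydrogen on the same aromatic carbon would fall relative to compound 1 and compound 4, and whether an amine or a carboxylic acid there would give a much larger step. A single pair also cannot show whether the same swap of methyl for trifluoromethyl would give a similar step on other aryl rings or on a different core.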